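The source may hold more compounds than are shown below. What is called first, only, known or untested is meant among the compounds shown, and "the series" means these compounds.

Compound 1 `O=C(NO)c1ccc(-c2cn([C@@H]3C[C@@H](CO)N(Cc4ccccc4)C3)nn2)cc1` and compound 2 `O=C(/C=C/c1cn([C@@H]2C[C@@H](CO)N(CCCc3ccccc3)C2)nn1)NO` share a core and differ both in the group that carries the hydroxycarbamoyl unit and in the chain on the ring nitrogen. In an assay on Sf9 cells for inhibition of histone deacetylase 11 (Homo sapiens), read by fluorescence, tested at 0.5 uM (a higher number here means more inhibition at the concentration tested (going by the name of the read-out), a lower number less inhibition), compound 1 gives < 10%, which is a limit of the assay and not a number. In this assay compound 2 gives 13%, the only actual number among the two results shown, so compound 2 cannot be ranked against compound 1. Compound 1 sits at the limit of < 10% in this assay, at which 1 of the 2 values shown sits. Compound 3 `O=C(NO)c1ccc(-c2cn([C@@H]3C[C@@H](CO)N(CCCc4ccccc4)C3)nn2)cc1` has not yet been measured. It differs from compound 2 in one place: 4-(hydroxycarbamoyl)phenyl in place of 2-(hydroxycarbamoyl)ethenyl on an aromatic carbon. Going by the values given here, no step between two measured compounds is available to size this change. Since compound 3 carries the same 4-(hydroxycarbamoyl)phenyl as compound 1, the step of a number 3 percentage points lower from compound 2 to compound 3 (within the scatter) is expected to stay within the usual scatter, or drift slightly downward. Compound 3 is therefore estimated at about 10%, between 0% and 25%.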

Compound 3, a percentage reported as inhibition, at one concentration (the size of the read-out at that concentration, not a potency): 14%
Estimate against measurement, compound 3: 4 percentage points below; the measured number falls inside the stated range.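

In this assay, placing 4-(hydroxycarbamoyl)phenyl instead of 2-(hydroxycarbamoyl)ethenyl on this aromatic carbon gives a number 1 percentage points higher from compound 2 to compound 3 (within the scatter), so at this single concentration the added six-membered aromatic ring leaves no readable mark. On the other side of the molecule, phenethyl in place of phenyl on the saturated chain carbon bound to the ring nitrogen gives a number at least 4 percentage points higher from compound 1 to compound 3 (that floor lies within the scatter). That step is only a floor, as the value of compound 1 is a limit of the assay and not a number: the limit of < 10% in this assay, at which 1 of the 3 values shown sits.

From the compounds shown here alone, it remains open whether a longer chain on the ring nitrogen, or an amine in place of the terminal phenyl ring of that chain, would move the reading beyond the scatter. Going by these compounds, the effect of a saturated two-carbon link in place of the ethenyl part at the triazole-bearing position is equally open.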